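A larger group on the carbonyl carbon of compound 3

The source may report more compounds than this note shows. Statements on the series, on what has been measured and on what is new or still open speak of the compounds shown alone.

Measured in an ADME assay on L02 cells (Homo sapiens) for antiproliferative activity, read by MTT assay, with a stated time of 48 h; a lower number here means a stronger inhibitor, a higher number a weaker inhibitor:
Compound 1 `CCn1c(C(=O)NCCCN(C)C)ccc1C(CC)(CC)c1ccc(OCCC(O)(CC)CC)c(C)c1`: 2420 nM
Compound 2 `CCn1c(C(=O)NCCN(C)C)ccc1C(CC)(CC)c1ccc(OCCC(O)(CC)CC)c(C)c1`: 990 nM
Compound 3 `C=CCN(C)C(=O)c1ccc(C(CC)(CC)c2ccc(OCCC(O)(CC)CC)c(C)c2)n1CC`: 1190 nM

Compound 3 sits second highest of these three numbers, but only compound 1 stands clearly apart from it. The data show a 2.0-fold lower number from compound 1 to compound 3 (0.31 log units; beyond the scatter), whereas they show a 1.2-fold higher number from compound 2 to compound 3 (0.08 log units; within the scatter), so compound 3 and compound 2 cannot be told apart.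

Compound 4 `CCC(C)C(NC(=O)c1ccc(C(CC)(CC)c2ccc(OCCC(O)(CC)CC)c(C)c2)n1CC)C(=O)OC` keeps the core of compound 3. On the carbonyl carbon, a group of 10 heavy atoms stands in place of allyl(methyl)amino: a group of 10 heavy atoms (7 carbon, 1 nitrogen, 2 oxygen; no ring) in place of a group of 5 heavy atoms (4 carbon, 1 nitrogen; no ring), on a carbonyl carbon.

Two measured steps swap the whole group at this same place, and they are the ones given above: one modest, one within the scatter. A third change, within the group itself, gave a 2.4-fold lower number from compound 1 to compound 2 (0.39 log units; beyond the scatter), which is also modest. For the measured compounds named here, no measured compound carries the entering group, so these steps suggest a likely size but no firm direction. In this assay, no step beyond the scatter is the best expectation, though a modest step either way remains possible.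

The expected step is a 1.3-fold higher number from compound 3 to compound 4 (0.10 log units; within the scatter). Compound 4 is estimated at 1500 nM, with an expected range of 550 nM to 4000 nM.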

Compound 4, half-maximal inhibitory concentration: > 50000 nM
Compound 4 ended at the assay's limit (the forecaster's own chance of this, stated with the estimate: 10%); middle value at least 33-fold (1.52 log units) from the limit.
By their numbers in this assay, from the lowest: compounds 2 and 3 (each within the scatter of the next); then compound 1. At a limit, above all of these: compound 4.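

Every earlier swap at this carbonyl carbon stayed modest or within the scatter, yet in this assay the group of 10 heavy atoms brings an at least 42-fold higher number from compound 3 to compound 4 (1.62 log units; beyond the scatter), so this position does not accept every group with so little effect. Compounds 1 and 2 carry an amide hydrogen as compound 4 does, and the change on that amide-type nitrogen is also large, with an at least 50-fold higher number from compound 2 to compound 4 (1.70 log units; beyond the scatter) and an at least 20-fold higher number from compound 1 to compound 4 (1.31 log units; beyond the scatter), so that hydrogen alone does not set compound 4 apart from them. The number for compound 4 is a limit of the assay and not an exact value, which makes all three steps minimum sizes: the limit of > 50000 nM in this assay, at which 1 of the 4 values shown sits.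

The ester and the branched carbon chain enter together in compound 4, so these compounds cannot show which part of the group goes with the loss of activity. From the compounds shown here alone, it also stays open whether a carboxylic acid in place of the ester, or a dimethylamino group at the end of the same chain, would bring the number back towards those of compounds 1, 2 and 3.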